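A chloro substituent on the pyrimidine amide

The compounds below may be only part of what the source reports. "The series", "measured", "known", "first", "only" and "open" are said of these compounds alone.

Compound 2 `COc1cc(N(C)C)c(NC(=O)c2ccncn2)cc1Nc1nccc(-c2cn(C)c3ccccc23)n1` and compound 1 `COc1cc(N(C)C)c(NC(=O)c2ccccn2)cc1Nc1nccc(-c2cn(C)c3ccccc23)n1` share one core. In a functional assay on A549 cells (Homo sapiens) for antiproliferative activity, read by MTT assay, with a stated time of 72 h (on this read-out lower numbers stand for stronger inhibition and higher numbers for weaker inhibition), compound 1 gives 8290 nM. In this assay compound 2 gives 5160 nM, and the step of a 1.6-fold lower number from compound 1 to compound 2 (0.21 log units; within the scatter) lies within the scatter, so the two numbers stand level. Compound 3 `COc1cc(N(C)C)c(NC(=O)c2ccnc(Cl)n2)cc1Nc1nccc(-c2cn(C)c3ccccc23)n1` differs from compound 2 by chloro in place of hydrogen on an aromatic carbon. Going by the values given here, no measured step touches this aromatic carbon, so nothing sets a direction. The expected step is therefore small, a 1.1-fold lower number from compound 2 to compound 3 (0.06 log units; within the scatter). Compound 3 is estimated at 4500 nM in this assay, within a range from 1500 nM to 13000 nM.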

Compound 3, half-maximal inhibitory concentration: 2840 nM
Beside the measured number, compound 3's estimate is 1.6-fold (0.20 log units) above it, and the stated range covers the measured number.
By their numbers in this assay, from the lowest: compounds 3, 2 and 1 (each within the scatter of the next, the first and the last beyond it).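

Chloro on the aromatic carbon between two ring nitrogen atoms is tolerated in this assay, and with a 1.8-fold lower number from compound 2 to compound 3 (0.26 log units; within the scatter) this single change does not separate the two compounds. Only the combined change of ring and chloro, with a 2.9-fold lower number from compound 1 to compound 3 (0.47 log units; beyond the scatter), gives a step beyond the scatter, and that step is modest. Nothing shown here offers an explanation for either step. From the compounds shown here alone, whether an amine, a methoxy group or a methyl group on this same carbon would behave like chloro stays open, as does the effect of a larger group there.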